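Amide replacement on the shared core: tolerability notes

A few compounds are considered here, and "the series" means these few. Any claim that something is new, unique, unknown or untested is made for them only; others in the source may bear on it.

Compound 1, `CC(C)n1ncc2c(C(=O)Nc3cccc(F)c3)cc(-c3cccs3)nc21`: in an ADME assay on LLC-MK2 cells (Macaca mulatta) for cytotoxicity, read by spectrophotometry and crystal violet staining, with a stated time of 4 days (a higher number here means that more compound is tolerated, a lower number that less compound is tolerated), compound 1 gives > 200000 nM, a limit of the assay rather than a number.
Compound 2, `CC(C)n1ncc2c(C(=O)N3CCc4cccnc43)cc(-c3cccs3)nc21`: in this assay compound 2 gives 50000 nM.
Compound 3, `CC(C)n1ncc2c(C(=O)Nc3ccccn3)cc(C3CC3)nc21`: in this assay compound 3 gives 25000 nM.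

For the measured compounds named here, compound 2 stands highest of the two numbers known, with compound 3 within the scatter of it and compound 1 known only as a limit. Compound 4, `CC(C)n1ncc2c(C(=O)Nc3ccc(F)c(F)c3)cc(-c3cccs3)nc21`, differs from compound 2 by a group of 9 heavy atoms (6 carbon, 1 nitrogen, 2 fluorine; one six-membered aromatic ring of carbon only) in place of a group of 9 heavy atoms (7 carbon, 2 nitrogen; one five-membered non-aromatic ring with 1 hetero atom, one six-membered aromatic ring with 1 hetero atom), on a carbonyl carbon. Going by the values given here, the one measured step that bears on this is an at least 4.0-fold lower number from compound 1 to compound 2 (0.60 log units; beyond the scatter), a closely related change run in the opposite direction, so the number for compound 4 is expected to climb, plausibly back to the limit of > 200000 nM in this assay, at which 1 of the 3 values shown sits. Compound 4 is therefore expected to give 150000 nM, within 50000 nM to 300000 nM. The expected step is a 3.0-fold higher number from compound 2 to compound 4 (0.48 log units; beyond the scatter).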

Compound 4, half-maximal cytotoxic concentration: > 200000 nM
Compound 4: no number, only a limit; the forecaster's own chance of this, stated with the estimate: 50%; at least 1.3-fold (0.12 log units) between middle value and limit.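

In this assay the change to (3,4-difluorophenyl)amino on the carbonyl carbon gives an at least 4.0-fold higher number from compound 2 to compound 4 (0.60 log units; beyond the scatter) and so shows that the lower number of compound 2 does not carry over to this amide. The step from compound 1 to compound 4 cannot be read. Of the three compounds sharing everything but this amide group, only compound 2 gives a number, and the other two stand at a limit: the limit of > 200000 nM in this assay, at which 2 of the 4 values shown sit.

As far as these compounds go, the true values of compound 1 and compound 4 stay open. Also open, from the compounds shown here alone, is where an open-chain dimethylamino group on this carbonyl carbon would fall.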